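This account rests on a few compounds, and the source may have more. Where it says the series, first, only, none or still open, it means among the compounds named here.

Compound 3 `O=c1cc(-c2ccccc2)oc2ccc(OCCCCCCN3CCCC(O)C3)cc12` gives 86 nM in an assay on isolated protein (Cavia porcellus) with Sigma non-opioid intracellular receptor 1 (Homo sapiens) as the target, read by radioligand binding (on this read-out lower numbers stand for stronger inhibition and higher numbers for weaker inhibition), the lowest number among the three measured compounds. Compound 1 `CN(C)CCCCCCCOc1ccc2oc(-c3ccccc3)cc(=O)c2c1` gives 165 nM, and compound 2 `CN(C)CCCCCCCCCOc1ccc2oc(-c3ccccc3)cc(=O)c2c1` gives 334 nM. The step of a 1.9-fold lower number from compound 1 to compound 3 (0.28 log units; within the scatter) lies within the scatter, whereas a 3.9-fold lower number from compound 2 to compound 3 (0.59 log units; beyond the scatter) is a modest change; the chain-length step a 2.0-fold higher number from compound 1 to compound 2 (0.31 log units; beyond the scatter) is also modest. Compound 4 `O=c1cc(-c2ccccc2)oc2ccc(OCCCCCCN3CCNCC3c3ncccn3)cc12` differs from compound 3 by 2-(pyrimidin-2-yl)piperazin-1-yl in place of 3-hydroxypiperidin-1-yl on a saturated chain carbon, six bonds along the chain from an oxygen on an aromatic ring. Only the two steps that alter the amine end bear on this change, and both were small, so a step of at most modest size is expected in this assay, with no clear direction. Compound 4 is therefore expected to give 150 nM, between 40 nM and 600 nM, which would mean a 1.7-fold higher number from compound 3 to compound 4 (0.24 log units; within the scatter).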

Compound 4, half-maximal inhibitory concentration: 1630 nM
Estimate against measurement, compound 4: 11-fold (1.04 log units) below; measured number above the stated range.
By their numbers in this assay, from the lowest: compounds 3 and 1 (each within the scatter of the next); then compound 2; then compound 4.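

Among these compounds, at this place, six bonds along the chain from an oxygen on an aromatic ring, the amine end proves far from interchangeable in this assay and 2-(pyrimidin-2-yl)piperazin-1-yl in place of 3-hydroxypiperidin-1-yl gives a 19-fold higher number from compound 3 to compound 4 (1.28 log units; beyond the scatter) as the only large step so far. Compound 4 also stands apart from the dimethylamino compounds, with a 9.9-fold higher number from compound 1 to compound 4 (0.99 log units; beyond the scatter) and a 4.9-fold higher number from compound 2 to compound 4 (0.69 log units; beyond the scatter) on top of that. No measurement here accounts for the size of this step.

From the compounds shown here alone, whether the pyrimidin-2-yl ring or the piperazine itself carries the step stays open, and a plain piperazin-1-yl on the same chain would separate the two. Also open, going by these compounds, is how 2-(pyrimidin-2-yl)piperazin-1-yl behaves on a longer chain.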